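A few compounds are considered here, and "the series" means these few. Any claim that something is new, unique, unknown or untested is made for them only; others in the source may bear on it.

Among the measured compounds shown here, compound 2 `CCC[C@@H](O)[C@H](O)[C@H](O)C[S@+]1C[C@@H](O)[C@H](O)[C@H]1CO` gives 5000 nM in an assay on intestine for inhibition of Maltase-glucoamylase (Homo sapiens) (a higher number here means a weaker inhibitor, a lower number a stronger inhibitor), the highest of the two numbers known so far. Compound 1 `CCCCCCCC[C@@H](O)[C@H](OS(=O)(=O)[O-])[C@H](O)C[S@+]1C[C@@H](O)[C@H](O)[C@H]1CO` gives 1200 nM in this assay, a lower number that lies beyond the scatter, though compound 1 differs from compound 2 in more than one place. Compound 3 `CCCCCCCC[C@@H](O)[C@H](O)[C@H](O)C[S@+]1C[C@@H](O)[C@H](O)[C@H]1CO` carries pentyl in place of hydrogen on a saturated chain carbon, four bonds along the chain from an oxygen on a saturated carbon. For the measured compounds named here, no measured pair shows this change alone, so a modest drop in the number is expected, estimated as a 2.5-fold lower number from compound 2 to compound 3 (0.40 log units; beyond the scatter). The value for compound 3 in this assay is estimated at 2000 nM, within a range from 700 nM to 6000 nM.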

Compound 3, half-maximal inhibitory concentration: 2000 nM
For compound 3 middle estimate and measured number coincide at the digits printed; the range from low to high includes it.
By their numbers in this assay, from the lowest: compounds 1 and 3 (each within the scatter of the next); then compound 2.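

In this assay pentyl in place of hydrogen on a saturated chain carbon gives a 2.5-fold lower number from compound 2 to compound 3 (0.40 log units; beyond the scatter) at this position, so the added chain alone moves the number beyond the scatter. Replacing the group of 4 heavy atoms on the oxygen with a hydrogen atom gives a 1.7-fold higher number from compound 1 to compound 3 (0.22 log units; within the scatter) and therefore no readable change in this pair. Nothing available explains either result. On these data alone, whether a longer chain than pentyl would lower the number further remains open. So does the effect of an amine at the end of the chain.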